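The compounds below may be only part of what the source reports. "The series", "measured", "known", "first", "only" and "open" are said of these compounds alone.

Three compounds of the series have numbers in a functional assay on the whole organism for inhibition, with Rattus norvegicus as the target, with a stated time of 7 h, at a dose of 1 mg/kg by the oral route; a lower number here means less inhibition, a higher number more inhibition at the dose given (going by the name of the read-out). Compound 1 `COc1nc2cccc(C(=O)O)c2n1Cc1ccc(-c2ccccc2-c2noc(O)n2)cc1` gives 88%, compound 2 `CCCOc1nc2cccc(C(=O)O)c2n1Cc1ccc(-c2ccccc2-c2noc(O)n2)cc1` gives 100% and compound 3 `CSc1nc2cccc(C(=O)O)c2n1Cc1ccc(-c2ccccc2-c2noc(O)n2)cc1` gives 100%. Compound 3 thus stands level with compound 2, the two together the highest of the three values; the step of a number 12 percentage points higher from compound 1 to compound 3 (beyond the scatter) lies beyond the scatter, whereas no change at the digits printed from compound 2 to compound 3 (within the scatter). Compound 4 `CCSc1nc2cccc(C(=O)O)c2n1Cc1ccc(-c2ccccc2-c2noc(O)n2)cc1` is not yet measured and differs from compound 3 by methyl in place of hydrogen on a saturated chain carbon bound to a sulfur. Among the measured compounds shown here, the only measured step of a related kind, ethyl in place of hydrogen on a saturated chain carbon bound to an oxygen on an aromatic ring, was a number 12 percentage points higher from compound 1 to compound 2 (beyond the scatter). The read-out of compound 3 already sits at the full value, so no step beyond the scatter is expected, no change at the digits printed from compound 3 to compound 4 (within the scatter). Compound 4 is estimated at 100% in this assay, between 90% and 100%.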

Compound 4, a percentage reported as inhibition, in the whole organism at one dose (the size of the read-out at that dose, not a potency): 100%
Beside the measured number, compound 4's estimate shows no gap at the digits printed, within the range that was stated.
By their numbers in this assay, from the lowest: compound 1; then compounds 2, 3 and 4 (each within the scatter of the next).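

In this assay, methyl in place of hydrogen on the sulfur-bound chain carbon leaves the read-out at its full value (no change at the digits printed from compound 3 to compound 4 (within the scatter)), so this position also accepts ethylsulfanyl. Against the oxygen-linked groups, ethylsulfanyl reads level with propoxy (no change at the digits printed from compound 2 to compound 4 (within the scatter)) and keeps the rise over methoxy (a number 12 percentage points higher from compound 1 to compound 4 (beyond the scatter)). No evidence bears on why these groups read alike.

With compound 2, compound 3 and compound 4 all at the full value, this single dose cannot separate them. Going by these compounds, how an amine or a longer chain at this position would read remains open.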